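Replacing the Cyano Group of Compound 3

A few compounds are considered here, and "the series" means these few. Any claim that something is new, unique, unknown or untested is made for them only; others in the source may bear on it.

In a functional assay for inhibition, with Homo sapiens as the target (on this read-out higher numbers stand for weaker inhibition and lower numbers for stronger inhibition), compound 1 `N#Cc1cc(-c2ccccc2)c2ccc(OCc3cccc(C4(O)CCOCC4)c3)cc2c1` gives 3 nM and compound 3 `N#Cc1cc(-c2ccoc2)c2ccc(OCc3cccc(C4(O)CCOCC4)c3)cc2c1` gives 2 nM. Between them lies a 1.5-fold lower number from compound 1 to compound 3 (0.18 log units; within the scatter), so these two sit together at the low end of the numbers, while compound 2 `O=C(O)c1cc(-c2ccccc2)c2ccc(OCc3cccc(C4(O)CCOCC4)c3)cc2c1` gives 190 nM. Compound 4 `CC1(C)COC(c2cc(-c3ccoc3)c3ccc(OCc4cccc(C5(O)CCOCC5)c4)cc3c2)=N1` alters compound 3 in one place: a group of 7 heavy atoms (5 carbon, 1 nitrogen, 1 oxygen; one five-membered non-aromatic ring with 2 hetero atoms) in place of a group of 2 heavy atoms (1 carbon, 1 nitrogen; no ring), on an aromatic carbon. Among the compounds with values here, one measured step touches that place, a 63-fold higher number from compound 1 to compound 2 (1.80 log units; beyond the scatter), where carboxy took the place of cyano. Within the data shown here, that large step shows that changes here can matter, but its entering group differs from the one in compound 4. A moderate rise is therefore expected, with the estimate being a 6.0-fold higher number from compound 3 to compound 4 (0.78 log units; beyond the scatter). Compound 4 is expected at 12 nM, with an estimated range of 3 nM to 60 nM.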

Compound 4, half-maximal inhibitory concentration: 17 nM
Beside the measured number, compound 4's estimate is 1.4-fold (0.15 log units) below it; the range from low to high includes it.
By their numbers in this assay, from the lowest: compounds 3 and 1 (each within the scatter of the next); then compound 4; then compound 2.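

Putting the larger ring group in place of the nitrile of compound 3 gives an 8.5-fold higher number from compound 3 to compound 4 (0.93 log units; beyond the scatter) in this assay and counts as a modest step. This position therefore accepts a much bulkier group with a five-membered non-aromatic ring and no net charge, at a real but limited cost in inhibition. Nothing shown here explains the size of this step.

On these data alone, whether a primary amide or a tetrazole would do better at this position stays open. So does the effect of carboxy when furan-3-yl is present.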